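The source may hold more compounds than are shown below. What is called first, only, known or untested is meant among the compounds shown, and "the series" means these compounds.

Measured compounds in an in vitro functional assay on HEK ts201 cells for antagonist activity at Neuronal acetylcholine receptor; alpha4/beta2 (Homo sapiens), read by fluorescence and calcium flux; a higher number here means a weaker inhibitor, a lower number a stronger inhibitor:
- compound 1 `CC1CC(=O)N(c2ccccc2C(=O)OCC2CCCN(CCCCCOc3ccccc3)C2)C1=O` gives 17000 nM
- compound 2 `O=C(Nc1cccc2ccccc12)c1ccccc1-c1ccccc1` gives 10700 nM
- compound 3 `O=C(OC1CCCN(CCCc2ccccc2)C1)c1ccccc1-c1ccccc1` gives 6500 nM

Compound 1 holds the highest number of the three in this assay. Compound 2 sits within the usual scatter of it, so no order between those two can be read from the numbers. Compound 3 gives a lower number than compound 1, and that gap lies beyond the scatter, so compound 3 reads as the stronger inhibitor of the pair. Within the data shown here, no pair of measured compounds differs in only one place, so no single-point step is available as a guide.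

Compound 4 `CC1CC(=O)N(c2ccccc2C(=O)OCC2CCCN(CCCCOc3ccccc3)C2)C1=O` is the next compound and differs from compound 1 in one place only:
phenoxy in place of phenoxymethyl on a saturated chain carbon, four bonds along the chain from an amine nitrogen in a ring

The change trims one saturated chain carbon from the linker between the ring amine nitrogen and the phenoxy group. Among the measured compounds shown here, nothing among the measured compounds shows what such a shortening does in this assay. The expected step of a 1.1-fold lower number from compound 1 to compound 4 (0.05 log units; within the scatter) is small and probably within the scatter, in either direction. Compound 4 is expected to give about 15000 nM, with a plausible range from 6000 nM to 40000 nM.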

Compound 4, half-maximal inhibitory concentration: 1700 nM
Compound 4: the middle estimate sits 8.8-fold (0.95 log units) above what was measured; the measured number lies below the stated range.
By their numbers in this assay, from the lowest: compound 4; then compounds 3, 2 and 1 (each within the scatter of the next, the first and the last beyond it).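

In this assay, the saturated chain carbon four bonds along from the ring amine nitrogen proves to be a sensitive place: phenoxy in place of phenoxymethyl there gives a 10-fold lower number from compound 1 to compound 4 (1.00 log units; beyond the scatter) with the rest of compound 1 unchanged. Among these compounds, this is the first single-point step, and it shows that the length of this chain alone can move the number beyond the scatter. No measured evidence on these compounds accounts for the size of the step.

From the compounds shown here alone, two chain lengths define no trend, so it remains open whether a 3-phenoxypropyl group would lower the number further or a longer chain than that of compound 1 would raise it. Also open, going by these compounds, is whether the phenoxy end is needed at all, or whether an amine or a carboxylic acid could stand in its place.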